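The source may report more compounds than this note shows. Statements on the series, on what has been measured and on what is new or still open speak of the compounds shown alone.

Compound 1 `COc1ccc(/C=C/C(=O)Nc2cc(C(=O)c3cc(OC)c(OC)c(OC)c3)ccc2OC)cc1` and compound 2 `COc1cccc(/C=C/C(=O)Nc2cc(C(=O)c3cc(OC)c(OC)c(OC)c3)ccc2OC)c1` share one core and differ only in the group at its far end: 3-methoxyphenyl in place of 4-methoxyphenyl on a double-bonded chain carbon bound to a double-bonded chain carbon. In a functional assay on HeLa cells (Homo sapiens) for cytotoxicity, read by MTT assay, with a stated time of 72 h (on this read-out higher numbers stand for weaker inhibition and lower numbers for stronger inhibition), compound 1 gives 10700 nM, while compound 2 gives 3100 nM. That step is a 3.5-fold lower number from compound 1 to compound 2 (0.54 log units; beyond the scatter). Compound 3 `COc1ccc(/C=C/C(=O)Nc2cc(C(=O)c3cc(OC)c(OC)c(OC)c3)cc(OC)c2OC)cc1` keeps the end group of compound 1 on a slightly altered core; the two cores differ by methoxy in place of hydrogen on an aromatic carbon. In this assay compound 3 gives 11200 nM, so the extra methoxy makes a 1.0-fold higher number from compound 1 to compound 3 (0.02 log units; within the scatter). Compound 4 `COc1cccc(/C=C/C(=O)Nc2cc(C(=O)c3cc(OC)c(OC)c(OC)c3)cc(OC)c2OC)c1` has not been measured. It differs from compound 3 by 3-methoxyphenyl in place of 4-methoxyphenyl on a double-bonded chain carbon bound to a double-bonded chain carbon, the same change that separates compound 1 from compound 2, at the same place. A step of similar size, a 3.5-fold lower number from compound 3 to compound 4 (0.54 log units; beyond the scatter), is expected because a 3.5-fold lower number from compound 1 to compound 2 (0.54 log units; beyond the scatter) was seen on the closely related core. Compound 4 is therefore estimated at 3200 nM in this assay, likely between 1500 nM and 7000 nM.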

Compound 4, half-maximal inhibitory concentration: 6900 nM
For compound 4 the middle estimate is 2.2-fold (0.33 log units) below the measured one; measured number inside the range.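

On the core of compound 3, 3-methoxyphenyl in place of 4-methoxyphenyl gives a 1.6-fold lower number from compound 3 to compound 4 (0.21 log units; within the scatter) in this assay, and this step does not differ measurably from the earlier one: the same change on two cores in this assay, a 3.5-fold lower number (0.54 log units; beyond the scatter) from compound 1 to compound 2 and a 1.6-fold lower number (0.21 log units; within the scatter) from compound 3 to compound 4, 2.1-fold (0.33 log units) apart, within the scatter of two such steps

The extra methoxy on the core, now with 3-methoxyphenyl at the far end, gives a 2.2-fold higher number from compound 2 to compound 4 (0.35 log units; beyond the scatter), and this too agrees with its earlier step: the same change on two cores in this assay, a 1.0-fold higher number (0.02 log units; within the scatter) from compound 1 to compound 3 and a 2.2-fold higher number (0.35 log units; beyond the scatter) from compound 2 to compound 4, 2.1-fold (0.33 log units) apart, within the scatter of two such steps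

Both changes are thus consistent with carrying over between these cores, but one pair of steps per change cannot show that their sizes are truly equal, nor does the step within the scatter on its own establish a real effect on that core.

Open, from the compounds shown here alone, is how an end ring with a hydroxyl or an amine in place of the methoxy would behave. Also open, going by these compounds, is whether either change would carry over to cores beyond these.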